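The compounds below may be only part of what the source reports. "The series", "measured", "known", "first", "only" and "open" are said of these compounds alone.

Of the compounds shown here, two built on the shared core have been measured so far in a functional assay on MIA PaCa-2 cells (Homo sapiens) for inhibition, read by MTT assay, with a stated time of 48 h, tested at 10 uM; on this read-out lower numbers stand for less inhibition of growth and higher numbers for more inhibition of growth at the one concentration tested. Compound 1 (`CN1CC[C@H](c2c(O)cc(O)c3c(=O)cc(/C=C/c4cccc(Cl)c4)oc23)[C@H](O)C1`) gives 52%, and compound 2 (`CN1CC[C@H](c2c(O)cc(O)c3c(=O)cc(/C=C/c4c(F)c(F)c(F)c(F)c4F)oc23)[C@H](O)C1`) gives 89%, so compound 2 stands as the higher of the two, clearly beyond the usual scatter. The next compound, compound 3 (`CN1CC[C@H](c2c(O)cc(O)c3c(=O)cc(/C=C/c4ccccc4Cl)oc23)[C@H](O)C1`), differs from compound 2 in one place: 2-chlorophenyl in place of 2,3,4,5,6-pentafluorophenyl on a double-bonded chain carbon bound to a double-bonded chain carbon. Among the measured compounds shown here, only one measured step bears on this change, namely a number 37 percentage points higher from compound 1 to compound 2 (beyond the scatter), which is large. That step brought the pentafluorophenyl group in and removed a chlorophenyl group, whereas the new change does the reverse. Compound 1 is therefore the closest guide, since it also carries a chlorophenyl group at this place, although not the same one. For the measured compounds named here, no measurement yet shows what moving the chlorine around that ring does, so the forecast stays loose. The expected change is a number 35 percentage points lower from compound 2 to compound 3 (beyond the scatter), a drop of similar size to the earlier rise and beyond the scatter. For compound 3 the estimated value is 54%, with an expected range from 34% to 74%.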

Compound 3, percent growth inhibition at one concentration: 59%
Beside the measured number, compound 3's estimate is 5 percentage points below it; the range from low to high includes it.
By their numbers in this assay, from the lowest: compounds 1 and 3 (each within the scatter of the next); then compound 2.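

In this assay, 2-chlorophenyl in place of 2,3,4,5,6-pentafluorophenyl on a double-bonded chain carbon bound to a double-bonded chain carbon gives a number 30 percentage points lower from compound 2 to compound 3 (beyond the scatter) and shows that a second chlorophenyl group also falls well short of compound 2, so the earlier gap was not peculiar to the 3-chlorophenyl group. The swap between the two chlorophenyl groups gives a number 7 percentage points higher from compound 1 to compound 3 (within the scatter) and shows that, for this pair, moving the chlorine around the ring makes no difference that can be told from the usual scatter. Why the pentafluorophenyl compound stands apart from both chlorophenyl compounds cannot be said, as no supporting information bears on it.

Still open, from the compounds shown here alone, is whether the high reading of compound 2 needs all five fluorine atoms, which a plain phenyl ring or a phenyl ring carrying a single fluorine atom would help to test. Going by these compounds, how a phenyl ring carrying a methoxy group, an amine or a carboxylic acid would read at this place also remains unknown.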